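A few compounds are considered here, and "the series" means these few. Any claim that something is new, unique, unknown or untested is made for them only; others in the source may bear on it.

Within the data shown here, compound 3 `Cc1ccc(-c2nn(CCCCN3CCN(CC4COc5ccccc5O4)CC3)c(=O)c3ccccc23)cc1` is one of three compounds measured in an assay on Cerebral cortex for displacement of a labelled ligand from Adrenergic receptor alpha-1 (Rattus norvegicus); a lower number here means a stronger inhibitor, a higher number a weaker inhibitor. Compound 3 gives 180 nM, the highest of the three numbers. Compound 2 `Cc1ccc(-c2nn(CCCCN3CCN(c4ccccc4)CC3)c(=O)c3ccccc23)cc1` gives 23.9 nM, and compound 1 `CCOc1ccccc1N1CCN(CCn2nc(-c3ccc(C)cc3)c3ccccc3c2=O)CC1` gives 3.9 nM. Compound 4 `Cc1ccc(-c2nn(CCCCN3CCN(c4ncccn4)CC3)c(=O)c3ccccc23)cc1` differs from compound 3 in one place: pyrimidin-2-yl in place of (2,3-dihydro-1,4-benzodioxin-2-yl)methyl on an amine nitrogen in a ring. Among the measured compounds shown here, one measured step bears on this: a 7.5-fold higher number from compound 2 to compound 3 (0.88 log units; beyond the scatter), where a phenyl on the same ring nitrogen was exchanged for the (2,3-dihydro-1,4-benzodioxin-2-yl)methyl group. Compound 4 carries an aromatic ring directly on that nitrogen, as compound 2 does, so a step back toward the number of compound 2 is expected, roughly a 4.5-fold lower number from compound 3 to compound 4 (0.65 log units; beyond the scatter). Compound 4 is therefore estimated at 40 nM, with a plausible range from 15 nM to 120 nM.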

Compound 4, inhibition constant: 270 nM
Compound 4: middle estimate off by 6.8-fold (0.83 log units), on the low side; the measured number lies above the stated range.
By their numbers in this assay, from the lowest: compound 1; then compound 2; then compounds 3 and 4 (each within the scatter of the next).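

In this assay, an aromatic ring on this amine nitrogen is not enough to keep the number low: pyrimidin-2-yl in place of phenyl gives an 11-fold higher number from compound 2 to compound 4 (1.05 log units; beyond the scatter) on the same core. Pyrimidin-2-yl in place of (2,3-dihydro-1,4-benzodioxin-2-yl)methyl gives a 1.5-fold higher number from compound 3 to compound 4 (0.18 log units; within the scatter) and so leaves these two groups indistinguishable here. No evidence is at hand to explain why pyrimidin-2-yl and phenyl differ.

Still open, going by these compounds, is whether pyridin-2-yl, a six-membered aromatic ring with a single nitrogen, would fall nearer phenyl or pyrimidin-2-yl.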